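The compounds below may be only part of what the source reports. "The series", "measured", "known", "first", "only" and "open" are said of these compounds alone.

Measured in a functional assay on LNCaP cells (Homo sapiens) for antiproliferative activity, read by propidium iodide staining, with a stated time of 96 h; on this read-out lower numbers stand for stronger inhibition and higher numbers for weaker inhibition:
Compound 1 `CC(O)(CSc1ccc(C(F)(F)F)cc1)C(=O)Nc1ccc(S(F)(F)(F)(F)F)cc1`: 17000 nM
Compound 2 `CC(O)(CSc1cccc(C(F)(F)F)c1)C(=O)Nc1ccc(S(F)(F)(F)(F)F)cc1`: 18300 nM
Compound 3 `CC(O)(CSc1cccc(OC(F)(F)F)c1)C(=O)Nc1ccc(S(F)(F)(F)(F)F)cc1`: 12800 nM

In this assay, compound 2 gives 18300 nM, a number within the scatter of both other compounds, so the three cannot be ranked. Compound 4 `CC(O)(CSc1cc(C(F)(F)F)cc(C(F)(F)F)c1)C(=O)Nc1ccc(S(F)(F)(F)(F)F)cc1` is compound 2 with trifluoromethyl in place of hydrogen on an aromatic carbon. Going by the values given here, two measured steps bear on this change, though only indirectly. Moving the trifluoromethyl group gave a 1.1-fold higher number from compound 1 to compound 2 (0.03 log units; within the scatter), and exchanging it for trifluoromethoxy gave a 1.4-fold lower number from compound 2 to compound 3 (0.16 log units; within the scatter). Neither step adds a group, so the series offers no direct measure of a second trifluoromethyl. Both steps are small, which gives no direction for compound 4, and no step beyond the scatter is expected. The estimated step is a 1.2-fold lower number from compound 2 to compound 4 (0.09 log units; within the scatter). On these data alone, the range is kept wide, since this kind of addition is untested here. For compound 4 the expected value is 15000 nM, with an estimated range from 6000 nM to 35000 nM.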

Compound 4, half-maximal inhibitory concentration: 17600 nM
Compound 4: the middle estimate sits 1.2-fold (0.07 log units) below what was measured, within the range that was stated.
By their numbers in this assay, from the lowest: compounds 3, 1, 4 and 2 (each within the scatter of the next).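

In this assay, going by these compounds alone, the addition of trifluoromethyl in place of hydrogen gave a 1.0-fold lower number from compound 2 to compound 4 (0.02 log units; within the scatter) and so supplied what the earlier compounds could not: a step that adds a group rather than moving or exchanging one. On this aromatic carbon, meta to a trifluoromethyl group, the four extra heavy atoms left the number within the scatter. The size of the entering group therefore made no readable difference at this position, at least for a second trifluoromethyl.

The compounds shown carry only trifluoromethyl or trifluoromethoxy on this ring, so it stays open whether an amine, a carboxylic acid or a nitrile on the same carbon would give a step beyond the scatter. No evidence is available on why this step is so small.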